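A few compounds are considered here, and "the series" means these few. Any claim that something is new, unique, unknown or untested is made for them only; others in the source may bear on it.

Measured so far, in an ADME assay on CCRF-CEM cells (Homo sapiens) for cytotoxicity, with a stated time of 3 days; a higher number here means that more compound is tolerated, a lower number that less compound is tolerated:
- compound 1 `Cc1ccc(Cn2c(=O)cc(C)n(C3C=CC(OC(=O)c4ccccc4)C3)c2=O)cc1` gives 20000 nM
- compound 2 `Cc1cc(C)cc(Cn2c(=O)ccn(C3C=CC(OC(=O)c4ccccc4)C3)c2=O)c1` gives 40000 nM
- compound 3 `Cc1cc(=O)[nH]c(=O)n1C1C=CC(OC(=O)c2ccccc2)C1` gives > 250000 nM, which is a limit of this assay rather than a number

Compound 2 and compound 1 are the two compounds with plain numbers, and the gap between them is within the usual scatter, so they cannot be told apart on these data. Within the data shown here, the only single-place step measured so far runs an at least 12-fold higher number from compound 1 to compound 3 (1.09 log units; beyond the scatter); its partner is the limit (the limit of > 250000 nM in this assay, at which 1 of the 3 values shown sits), so its true size is not known.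

The unmeasured compound 4 `O=C(OC1C=CC(n2ccc(=O)n(Cc3cc(F)cc(F)c3)c2=O)C1)c1ccccc1` differs from compound 2 in one place: 3,5-difluorophenyl in place of 3,5-dimethylphenyl on a saturated chain carbon bound to an aromatic nitrogen. The measured step concerns removing the whole benzyl group on the aromatic nitrogen, whereas the change to compound 4 keeps that group and only swaps what sits on its ring. Among the measured compounds shown here, no measured step therefore speaks to this swap, and no movement beyond the scatter is expected in this assay.

Compound 4 is accordingly expected to give 40000 nM, with a range from 15000 nM to 110000 nM. This estimate means an expected step of no change at the digits printed from compound 2 to compound 4 (within the scatter).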

Compound 4, half-maximal cytotoxic concentration: 32000 nM
Compound 4: the middle estimate sits 1.3-fold (0.10 log units) above what was measured, within the range that was stated.
By their numbers in this assay, from the lowest: compounds 1, 4 and 2 (each within the scatter of the next). At a limit, above all of these: compound 3.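

Putting 3,5-difluorophenyl in place of 3,5-dimethylphenyl on a saturated chain carbon bound to an aromatic nitrogen gives a 1.3-fold lower number from compound 2 to compound 4 (0.10 log units; within the scatter) in this assay and so leaves the two compounds indistinguishable. Among these compounds, the one earlier single-place step removed the whole 4-methylbenzyl group from the aromatic nitrogen, whereas this step keeps a benzyl group there and changes only what its ring carries, showing that for this one pair, two fluorine atoms and two methyl groups at these ring places cannot be told apart in this measurement. The compounds shown give no measured property that would explain why this swap leaves the number within the scatter.

As far as these compounds go, this is a single pair, so it remains open whether the same holds for other groups on that ring, such as a carboxylic acid or an amine, or for a longer chain joining the ring to the aromatic nitrogen. It also remains open how the number would respond to replacing the benzoate ester at the other end of the molecule, which is the same in all the compounds shown.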